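Swapping a hexyl chain for an aromatic ring

The compounds below may be only part of what the source reports. "The series", "measured", "known", "first", "only" and "open" are said of these compounds alone.

Of the compounds shown here, three sharing one core have been measured in an assay on membranes from brain for displacement of a labelled ligand from Sigma non-opioid intracellular receptor 1 (Cavia porcellus), read by scintillation counting, with a stated time of 120 min; a lower number here means a stronger inhibitor, a higher number a weaker inhibitor. Compound 1 `Cc1cccc2sc(NC(=O)CCN3CCN(C(C)C)CC3)nc12` gives 1300 nM. Compound 2 `Cc1cccc2sc(NC(=O)CCN3CCN(CCCN(C)C)CC3)nc12` gives 570 nM, and compound 3 `CCCCCCN1CCN(CCC(=O)Nc2nc3c(C)cccc3s2)CC1` gives 238 nM, the lowest number of the three. The steps of a 2.3-fold lower number from compound 1 to compound 2 (0.36 log units; beyond the scatter) and a 5.5-fold lower number from compound 1 to compound 3 (0.74 log units; beyond the scatter) both replace the isopropyl group on the amine nitrogen in a ring, and a 2.4-fold lower number from compound 2 to compound 3 (0.38 log units; beyond the scatter) alters the chain on that same nitrogen. Compound 4 `Cc1ccccc1N1CCN(CCC(=O)Nc2nc3c(C)cccc3s2)CC1` changes the same position: 2-methylphenyl in place of hexyl on an amine nitrogen in a ring. For the measured compounds named here, no measured step introduces an aromatic ring there, so the earlier steps only show that replacing the isopropyl group has lowered the number. A modest step in either direction is expected, estimated as a 1.3-fold higher number from compound 3 to compound 4 (0.10 log units; within the scatter). Compound 4 is therefore expected near 300 nM, within 80 nM to 1100 nM.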

Compound 4, inhibition constant: 1000 nM
Beside the measured number, compound 4's estimate is 3.3-fold (0.52 log units) below it; low and high end bracket the measured number.
By their numbers in this assay, from the lowest: compound 3; then compounds 2, 4 and 1 (each within the scatter of the next, the first and the last beyond it).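

An aromatic ring on this ring nitrogen does not reproduce what the hexyl chain gives: 2-methylphenyl in place of hexyl produces a step beyond the scatter (a 4.2-fold higher number from compound 3 to compound 4 (0.62 log units; beyond the scatter)). Compound 4 cannot be told apart from the compounds carrying 3-(dimethylamino)propyl (a 1.8-fold higher number from compound 2 to compound 4 (0.24 log units; within the scatter)) or isopropyl (a 1.3-fold lower number from compound 1 to compound 4 (0.11 log units; within the scatter)), as both steps lie within the scatter. No measured evidence accounts for the hexyl result. Still open, as far as these compounds go, is whether a plain phenyl, a benzyl group or a chain longer than hexyl on this nitrogen would give a number nearer that of compound 3 or that of compound 4.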